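Solubility of Three Measured Compounds and a Dimethylphenyl Analogue

A few compounds are considered here, and "the series" means these few. Any claim that something is new, unique, unknown or untested is made for them only; others in the source may bear on it.

Measured so far:
compound 1 `COc1ccc(-c2cnn3c(NCc4ccccn4)cc(C)nc23)cc1` — < 5000 nM
compound 2 `Cc1cc(NCc2ccccn2)n2ncc(-c3cccc(Cl)c3)c2n1` — < 5000 nM
compound 3 `Cc1cc(NCc2ccccn2)n2ncc(-c3ccc(F)c(Cl)c3)c2n1` — < 5000 nM

In a physicochemical assay for solubility, read by HPLC, using the shake flask method, measured as kinetic solubility, with a stated time of 2 h, at pH 7.4 (on this read-out lower numbers stand for lower solubility and higher numbers for higher solubility), compound 1 gives < 5000 nM, which is a limit of the assay and not a number. Compound 2 gives < 5000 nM, also a limit. Compound 3 gives < 5000 nM, again a limit. The steps a step that the two limits leave unreadable from compound 1 to compound 2, a step that the two limits leave unreadable from compound 1 to compound 3 and a step that the two limits leave unreadable from compound 2 to compound 3 therefore cannot be sized, since (the limit of < 5000 nM in this assay, at which 3 of the 3 values shown sit).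

Compound 4 `Cc1cc(NCc2ccccn2)n2ncc(-c3c(C)cccc3C)c2n1` differs from compound 3 by 2,6-dimethylphenyl in place of 3-chloro-4-fluorophenyl on an aromatic carbon. Going by the values given here, no measured step readably bears on this change. Compound 4 is expected to give 2000 nM in this assay, with a range of 300 nM to 8000 nM, most likely again reported as a limit. The expected step is a step that the limit leaves unreadable from compound 3 to compound 4.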

Compound 4, solubility: < 5000 nM
Compound 4 gave a limit, no number; the forecaster's own chance of this, stated with the estimate: 75%; the middle value is on the limit's open side.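

Compound 4 gives no step that can be read against compound 1, compound 2 or compound 3, because all of their values are limits: the limit of < 5000 nM in this assay, at which 4 of the 4 values shown sit.

On these data alone, how far the solubilities of these four compounds actually lie from one another stays open.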